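Acetyl for 4-chlorobenzyl on a ring amine nitrogen

The source may hold more compounds than are shown below. What is called first, only, known or untested is meant among the compounds shown, and "the series" means these compounds.

Compound 1 (`NC(=O)c1ccc2[nH]c(-c3ccc(OCCCO)cc3)nc2c1`), compound 2 (`NC(=O)c1ccc2[nH]c(-c3ccc(OCC4CCCNC4)cc3)nc2c1`) and compound 3 (`NC(=O)c1ccc2[nH]c(-c3ccc(OCCC4CCN(Cc5ccc(Cl)cc5)CC4)cc3)nc2c1`) share the same core. In a physicochemical assay for solubility, with a stated time of 3 days, at pH 7 (a higher number here means a more soluble compound, a lower number a less soluble compound), compound 1 gives 7000 nM, while for compound 2 the entry reads "not determined" (no result reported). Compound 3 gives 2000 nM, the lower of the two available numbers, and the gap to compound 1 lies beyond the scatter.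

Going from compound 3 to compound 4 (`CC(=O)N1CCC(CCOc2ccc(-c3nc4cc(C(N)=O)ccc4[nH]3)cc2)CC1`), acetyl takes the place of 4-chlorobenzyl on an amine nitrogen in a ring (acetyl in place of 4-chlorobenzyl on an amine nitrogen in a ring). Among the measured compounds shown here, no measured pair isolates this change, so the expectation rests on thin evidence. The main guide is compound 1, which carries no 4-chlorobenzyl and gives 7000 nM. An upward step in this assay is expected, beyond the scatter, and is estimated as a 4.0-fold higher number from compound 3 to compound 4 (0.60 log units; beyond the scatter). For compound 4 the estimated value is 8000 nM, with an expected range of 2500 nM to 30000 nM.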

Compound 4, solubility: 2000 nM
Beside the measured number, compound 4's estimate is 4.0-fold (0.60 log units) above it; the measured number lies below the stated range.
By their numbers in this assay, from the lowest: compounds 3 and 4 (each within the scatter of the next); then compound 1.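

On the amine nitrogen in the six-membered non-aromatic ring, acetyl in place of 4-chlorobenzyl gives no change at the digits printed from compound 3 to compound 4 (within the scatter) in this assay so the two groups cannot be told apart in this read-out, even though only one of them carries an aromatic ring. The distance from compound 1 remains: 1-acetylpiperidin-4-yl in place of hydroxymethyl on a saturated chain carbon gives a 3.5-fold lower number from compound 1 to compound 4 (0.54 log units; beyond the scatter) so among the compounds with numbers, the lower values belong to the two that carry the substituted ring, whichever group sits on its nitrogen. Nothing measured here accounts for these numbers.

From the compounds shown here alone, it remains open how the free amine, or a methanesulfonyl group on that same nitrogen, would read in this assay and whether any group there can bring the number back towards that of compound 1. A longer chain between the ether oxygen and the ring is equally unresolved.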